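The source may report more compounds than this note shows. Statements on the series, on what has been measured and on what is new or still open speak of the compounds shown alone.

Measured so far:
- compound 1, `CCCNC(=O)c1cc(Oc2ccc(NC(=O)c3cc4cccnc4n(-c4ccccc4)c3=O)cc2)ccn1`: 1510 nM in a functional assay on U-87MG ATCC cells for antiproliferative activity against U-87 MG (Homo sapiens), read by MTT assay, with a stated time of 72 h; on this read-out higher numbers stand for weaker inhibition and lower numbers for stronger inhibition
- compound 2, `CCCNC(=O)c1cc(Oc2ccc(NC(=O)c3cc4cccnc4n(-c4ccc(Br)cc4F)c3=O)cc2)ccn1`: "not determined" (no result reported) in this assay

Compound 2 carries a 4-bromo-2-fluorophenyl on an aromatic nitrogen of the shared core, yet stands nowhere on the numbers: no value exists for it. Compound 3, `CCCNC(=O)c1cc(Oc2ccc(NC(=O)c3cc4cccnc4n(-c4ccc(C(F)(F)F)cc4Cl)c3=O)cc2)ccn1`, differs from compound 2 only by 2-chloro-4-(trifluoromethyl)phenyl in place of 4-bromo-2-fluorophenyl on an aromatic nitrogen. Among the compounds with values here, no measured pair shows what such a swap does, so no step beyond the scatter can be expected in either direction. Compound 3 is therefore expected to give about 900 nM, somewhere between 150 nM and 5000 nM.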

Compound 3, half-maximal inhibitory concentration: 10900 nM
The estimate for compound 3 lay 12-fold (1.08 log units) below the measured number; measured number outside the range, above it.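

In this assay the group on the aromatic nitrogen of the shared core clearly matters: 2-chloro-4-(trifluoromethyl)phenyl in place of phenyl gives a 7.2-fold higher number from compound 1 to compound 3 (0.86 log units; beyond the scatter) and so weakens inhibition beyond the scatter. The step from compound 2 cannot be read, as compound 2 has no value. No measurement shown explains the rise. Which of the two added groups, chloro or trifluoromethyl, carries the step stays open. So does what an amine or a carboxylic acid on this phenyl would do.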